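Removing the nitro group from compound 3

This account rests on a few compounds, and the source may have more. Where it says the series, first, only, none or still open, it means among the compounds named here.

Compound 3, `O=[N+]([O-])c1ccc(COc2ccc(Nc3ncnc4cc5c(cc34)OCCOCCOCCOCCO5)cc2)cc1`, carries a nitro group on the benzyloxy ring attached to the shared core. In a functional assay on A549 cells (Homo sapiens) for antiproliferative activity, read by MTT assay, with a stated time of 72 h (a higher number here means a weaker inhibitor, a lower number a stronger inhibitor), compound 3 gives only a limit, > 100000 nM, and not a number. Its closest measured relative is compound 2, `FC(F)(F)c1ccc(COc2ccc(Nc3ncnc4cc5c(cc34)OCCOCCOCCOCCO5)cc2)cc1`, which in this assay gives 8560 nM. Going by the values given here, the one measured step that bears on the change at hand is an at least 11-fold higher number from compound 2 to compound 3 (1.06 log units; beyond the scatter); that the nitro compound sits at the limit of > 100000 nM in this assay, at which 1 of the 3 values shown sits, means the true size of this step is not known beyond its lower bound. Compound 1, `c1ccc(COc2ccc(Nc3ncnc4cc5c(cc34)OCCOCCO5)cc2)cc1`, differs from the others in the shorter ring of oxygens and carbons fused to the core, and in this assay compound 1 gives 43900 nM, so an unsubstituted benzyl group on a related core gives a measurable number.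

Compound 4, `c1ccc(COc2ccc(Nc3ncnc4cc5c(cc34)OCCOCCOCCOCCO5)cc2)cc1`, is the unsubstituted partner of compound 3: hydrogen in place of nitro on an aromatic carbon. Since the nitro group went with a large loss against the trifluoromethyl compound, its removal is expected to bring a clear gain in this assay, which is the step of an at least 4.0-fold lower number from compound 3 to compound 4 (0.60 log units; beyond the scatter) from compound 3 to compound 4. Compound 4 is therefore estimated at 25000 nM, within a range from 8000 nM to 80000 nM, leaning on the numbers of compound 2 and compound 1.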

Compound 4, half-maximal inhibitory concentration: 29500 nM
Beside the measured number, compound 4's estimate is 1.2-fold (0.07 log units) below it; the measured number falls inside the stated range.
By their numbers in this assay, from the lowest: compound 2; then compounds 4 and 1 (each within the scatter of the next). At a limit, above all of these: compound 3.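

In this assay, the place on the benzyloxy ring now carries three groups on one shared core, and the unsubstituted partner separates two effects that compound 2 and compound 3 alone could not: replacing nitro with hydrogen gives an at least 3.3-fold lower number from compound 3 to compound 4 (0.53 log units; beyond the scatter), while replacing trifluoromethyl with hydrogen gives a 3.4-fold higher number from compound 2 to compound 4 (0.54 log units; beyond the scatter). Hydrogen therefore falls between the two groups, so the large step between compound 2 and compound 3 is not simply the loss of a benefit from trifluoromethyl, since nitro also stands on the weaker side of hydrogen. The gain on removing nitro remains only a lower bound because compound 3 gives a limit and not a number: the limit of > 100000 nM in this assay, at which 1 of the 4 values shown sits.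

The compounds shown leave open where an amine, a methoxy group or a carboxylic acid would fall in this order at the same place, and whether any group there would give a lower number than trifluoromethyl. They also leave open whether the order holds on the core of compound 1, which appears here only with the unsubstituted benzyl group.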